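A further amide at the limit of cytotoxicity

The compounds below may be only part of what the source reports. "The series", "measured", "known", "first", "only" and "open" are said of these compounds alone.

Compound 1 `Cc1cc(C#N)cc(C)c1Oc1nc(Nc2ccc(C#N)cc2)ncc1/C=C/C(=O)NC1CC1` gives > 221 nM as a limit.
Compound 2 `Cc1cc(C#N)cc(C)c1Oc1nc(Nc2ccc(C#N)cc2)ncc1/C=C/C(=O)NCCOCCO` gives > 200 nM as a limit.

In an ADME assay on TZM cells (Homo sapiens) for cytotoxicity, with a stated time of 1 days (a lower number here means that less compound is tolerated, a higher number that more compound is tolerated), compound 2 stands only at the limit > 200 nM and has no number. Compound 3 `Cc1cc(C#N)cc(C)c1Oc1nc(Nc2ccc(C#N)cc2)ncc1/C=C/C(=O)NC1CCN(S(C)(=O)=O)C1` carries 1-(methylsulfonyl)pyrrolidin-3-yl in place of 2-(2-hydroxyethoxy)ethyl on an amide-type nitrogen. For the measured compounds named here, the one measured change at that nitrogen is a step that the two limits leave unreadable from compound 1 to compound 2, so it offers no size to carry over. No step beyond the scatter is expected in this assay, in either direction, and another limit is the likeliest report. Compound 3 is estimated at 200 nM, with an expected range of 100 nM to 1500 nM. This estimate amounts to an expected a number no higher from compound 2 to compound 3 (the limit leaves the size open).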

Compound 3, half-maximal cytotoxic concentration: > 179 nM
Compound 3: only a limit was reported; the forecaster's own chance of this, stated with the estimate: 85%; the middle value lies beyond the limit too.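

In this assay compound 3 gives only a limit, > 179 nM, so its steps from compound 1 and compound 2 cannot be read. The compounds shown leave open whether these three amide substituents differ in cytotoxicity at all.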